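From Methylsulfanyl to Dimethylamino on a Shared Core

A few compounds are considered here, and "the series" means these few. Any claim that something is new, unique, unknown or untested is made for them only; others in the source may bear on it.

Three measured compounds share one core. Compound 1 `CCCc1ncn2c(SC)nncc12` carries a propyl group on an aromatic carbon; compound 2 `CSc1nncc2c(C(C)C)ncn12` has isopropyl in place of propyl on an aromatic carbon; compound 3 `CSc1nncc2c(C)ncn12` has methyl in place of isopropyl on an aromatic carbon. In a functional assay for inhibition, with Homo sapiens as the target (on this read-out higher numbers stand for weaker inhibition and lower numbers for stronger inhibition), compound 1 gives > 48000 nM, which is a limit of the assay and not a number. In this assay compound 2 gives > 48000 nM, likewise a limit. In this assay compound 3 gives > 48000 nM, again only a limit. The three steps are therefore a step that the two limits leave unreadable from compound 1 to compound 2, a step that the two limits leave unreadable from compound 1 to compound 3 and a step that the two limits leave unreadable from compound 2 to compound 3; all that can be said is the limit of > 48000 nM in this assay, at which 3 of the 3 values shown sit. Compound 3 thus stands at the limit, as do the other two.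

Compound 4 `Cc1ncn2c(N(C)C)nncc12` differs from compound 3 by dimethylamino in place of methylsulfanyl on an aromatic carbon. For the measured compounds named here, no measured step touches this change, and none of the three steps can be sized, so no direction can be read for it in this assay. Because of the limit of > 48000 nM in this assay, at which 3 of the 3 values shown sit, compound 4 is expected to give 60000 nM, within a range from 20000 nM to 200000 nM. This corresponds to an expected step that the limit leaves unreadable from compound 3 to compound 4, most probably reported once more as a limit rather than a number.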

Compound 4, half-maximal inhibitory concentration: > 48000 nM
Compound 4: no number, only a limit; the forecaster's own chance of this, stated with the estimate: 80%; the middle value does not contradict the limit.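

In this assay compound 4 gives > 48000 nM, which is a limit of the assay and not a number. No size can be read for the step from compound 3 to compound 4, and the four compounds end at one shared result: the limit of > 48000 nM in this assay, at which 4 of the 4 values shown sit. The compounds shown leave open whether any change on the shared core would give a readable inhibition value.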